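The source may hold more compounds than are shown below. What is called first, only, known or untested is meant among the compounds shown, and "the series" means these compounds.

Two compounds from this series have been run through an assay on brain for displacement of a labelled ligand from D(3) dopamine receptor (Rattus norvegicus); a lower number here means a stronger inhibitor, a higher number a weaker inhibitor. Compound 1, `CCCN(CC[C@H]1CC[C@H](NC(=O)/C=C/c2ccccc2Cl)CC1)[C@H]1CCc2nc(N)sc2C1`, gives 1.2 nM in this assay. Compound 2, `CCCN(CC[C@H]1CC[C@H](NC(=O)/C=C/c2cccc(OC)c2)CC1)[C@H]1CCc2nc(N)sc2C1`, gives 9.3 nM, the higher of the two numbers shown. Among the compounds with values here, the only measured step connecting them, a 7.8-fold higher number from compound 1 to compound 2 (0.89 log units; beyond the scatter), shows that exchanging the aromatic ring on the double-bonded chain carbon moves the readout by a modest but real amount.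

Compound 3, `CCCN(CC[C@H]1CC[C@H](NC(=O)c2cccc3ncccc23)CC1)[C@H]1CCc2nc(N)sc2C1`, differs from compound 2 in one place: quinolin-5-yl in place of 2-(3-methoxyphenyl)ethenyl on a carbonyl carbon. Within the data shown here, no measured step covers this exact exchange, so the bearing of the one known step is indirect; it indicates only that the group on the carbonyl carbon can shift this assay by about that size in either direction. The ring count and acceptor count are unchanged. Compound 3 is therefore expected to give 3 nM, within a range of 0.7 nM to 15 nM, which amounts to an expected step of a 3.1-fold lower number from compound 2 to compound 3 (0.49 log units; beyond the scatter).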

Compound 3, inhibition constant: 1.6 nM
Compound 3: middle estimate off by 1.9-fold (0.27 log units), on the high side, and the stated range covers the measured number.
By their numbers in this assay, from the lowest: compounds 1 and 3 (each within the scatter of the next); then compound 2.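

Read in this assay, the step of a 5.8-fold lower number from compound 2 to compound 3 (0.76 log units; beyond the scatter) shows that the group on the carbonyl carbon need not keep the ethenyl chain for a low number, since quinolin-5-yl, with its two six-membered aromatic rings, gives a lower number than 2-(3-methoxyphenyl)ethenyl. The step of a 1.3-fold higher number from compound 1 to compound 3 (0.12 log units; within the scatter) lies within the scatter, so quinolin-5-yl and 2-(2-chlorophenyl)ethenyl cannot be told apart in this assay, and two quite different groups on this carbon give equivalent results. Nothing available accounts for these differences or this equivalence.

The compounds shown leave open whether the ring nitrogen of quinolin-5-yl matters, a question that a naphthalen-1-yl group, with carbon in its place, would address. Going by these compounds, it also remains open whether a plain phenyl group on the carbonyl carbon would match these numbers.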